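From a Hydroxyethyl Tail to a Benzyl Tail

The source may report more compounds than this note shows. Statements on the series, on what has been measured and on what is new or still open speak of the compounds shown alone.

Measured compounds:
Compound 1 `CCCCNC(=N)N1C[C@H](O)[C@@H](O)[C@H](O)[C@H]1CO`: 15000 nM
Compound 2 `N=C(NCCO)N1C[C@H](O)[C@@H](O)[C@H](O)[C@H]1CO`: > 1000000 nM

Both were tested in an assay for inhibition of beta-galactosidase (Bos taurus), read by spectrophotometry, with a stated time of 30 min; on this read-out higher numbers stand for weaker inhibition and lower numbers for stronger inhibition. Compound 1 gives 15000 nM. For compound 2 the result is only a limit of the assay, > 1000000 nM, so no number is known for it. Going by the values given here, the single measured step, an at least 66-fold higher number from compound 1 to compound 2 (1.82 log units; beyond the scatter), is large, and the weaker partner sits at the limit of > 1000000 nM in this assay, at which 1 of the 2 values shown sits.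

Compound 3 `N=C(NCc1ccccc1)N1C[C@H](O)[C@@H](O)[C@H](O)[C@H]1CO` differs from compound 2 by phenyl in place of hydroxymethyl on a saturated chain carbon bound to an amine nitrogen. This undoes the hydroxy that the step of an at least 66-fold higher number from compound 1 to compound 2 (1.82 log units; beyond the scatter) showed to be so costly, and brings in an aromatic ring in its place, so a large move toward stronger inhibition is expected, back to roughly where compound 1 stands. In this assay compound 3 is estimated at 12000 nM, with a range of 2000 nM to 80000 nM. The expected step would then be an at least 83-fold lower number from compound 2 to compound 3 (1.92 log units; beyond the scatter).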

Compound 3, half-maximal inhibitory concentration: 5100 nM
Beside the measured number, compound 3's estimate is 2.4-fold (0.37 log units) above it; low and high end bracket the measured number.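

Swapping hydroxymethyl for phenyl gives an at least 190-fold lower number from compound 2 to compound 3 (2.29 log units; beyond the scatter), so the tail at this place can move the result a long way while the shared core stays the same. Compound 2 itself is only a limit of the assay, not a number: the limit of > 1000000 nM in this assay, at which 1 of the 3 values shown sits. An aromatic ring is also more than merely accepted here, because the benzyl tail of compound 3 goes past the plain chain of compound 1, with a 2.9-fold lower number from compound 1 to compound 3 (0.47 log units; beyond the scatter), a modest step but one beyond the scatter.

From the compounds shown here alone, whether this step belongs to the aromatic ring or simply to a tail of carbon atoms remains open, and a cyclohexylmethyl tail would help to separate the two. Going by these compounds, how a fluorine on the phenyl ring or a longer 2-phenylethyl tail would read also remains open.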